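The source may report more compounds than this note shows. Statements on the series, on what has been measured and on what is new or still open speak of the compounds shown alone.

Series notes, antiproliferative data. In a functional assay on Daudi cells (Homo sapiens) for antiproliferative activity (a lower number here means a stronger inhibitor, a higher number a weaker inhibitor), compound 1 `Nc1ncnc2c1c(-c1cc3ccccc3o1)cn2[C@H]1CCN(C[C@@H]2CO2)C1` gives 4510 nM and compound 2 `Nc1ncnc2c1c(-c1ccc(Oc3ccccc3)cc1)cn2C[C@H]1CCCN1C(CO)CO` gives 28200 nM. Compound 2 therefore has the higher of the two numbers, which makes it the weaker inhibitor of the pair by a gap beyond the scatter.

Compound 3 `Nc1ncnc2c1c(-c1ccc(Oc3ccccc3)cc1)cn2[C@H]1CCN(C[C@H]2CO2)C1` keeps the rest of compound 2 and changes only the substituent on an aromatic nitrogen of the five-membered aromatic ring: 1-((oxiran-2-yl)methyl)pyrrolidin-3-yl in place of (1-(2-hydroxy-1-(hydroxymethyl)ethyl)pyrrolidin-2-yl)methyl on an aromatic nitrogen. The diol-bearing chain is lost, and an oxirane-capped pyrrolidine takes its place. Going by the values given here, compound 1 carries a group of the same name, differing at one defined stereocentre, and its value of 4510 nM is the only guide to how this group behaves in this assay. Among the compounds with values here, no measured pair isolates the change, so the size of the step remains uncertain.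

A drop beyond the scatter is expected, towards the level of compound 1. The estimated change is a 9.4-fold lower number from compound 2 to compound 3 (0.97 log units; beyond the scatter). For compound 3 the expected value is 3000 nM, with an estimated range of 500 nM to 15000 nM.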

Compound 3, half-maximal inhibitory concentration: 15700 nM
Estimate against measurement, compound 3: 5.2-fold (0.72 log units) below; the measured number lies above the stated range.
By their numbers in this assay, from the lowest: compound 1; then compounds 3 and 2 (each within the scatter of the next).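

In this assay, the exchange at this aromatic nitrogen comes to a 1.8-fold lower number from compound 2 to compound 3 (0.25 log units; within the scatter), which places the two compounds within the scatter of each other. On this phenoxyphenyl-bearing core, then, the position accepts 1-((oxiran-2-yl)methyl)pyrrolidin-3-yl in place of (1-(2-hydroxy-1-(hydroxymethyl)ethyl)pyrrolidin-2-yl)methyl with no difference that can be told from ordinary assay variation, although the diol-bearing chain is gone and an oxirane ring has entered. Going by these compounds alone, no measurement offered here accounts for this result, and the single step cannot separate the contributions of the parts exchanged within the substituent.

From the compounds shown here alone, compound 1 differs from compound 3 both in its aromatic group and at a defined stereocentre, so the pair cannot be read as a step, and the separate effects of those two differences remain open. Also open, going by these compounds, is how the value at this position would respond if the oxirane-capped chain gave way to a simple pyrrolidin-3-yl carrying a free secondary amine or to an acryloyl group on the pyrrolidine nitrogen.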